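Swapping the Terminal Aryl Group: Expected Cytotoxicity of Compound 3

The source may hold more compounds than are shown below. What is called first, only, known or untested is meant among the compounds shown, and "the series" means these compounds.

Measured compounds:
- compound 1, `CN(C)CCn1cnnc1-c1cc(Oc2ccc(NC(=O)N/N=C/c3c(Cl)cccc3Cl)cc2F)ccn1`; in an ADME assay on WI-38 cells (Homo sapiens) for cytotoxicity, read by MTT assay, with a stated time of 72 h (on this read-out lower numbers stand for stronger inhibition and higher numbers for weaker inhibition), compound 1 gives 3320 nM
- compound 2, `COc1ccc(/C=N/NC(=O)Nc2ccc(Oc3ccnc(-c4nncn4CCN(C)C)c3)c(F)c2)c(OC)c1`; in this assay compound 2 gives 6630 nM

For the measured compounds named here, compound 2 has the highest of the two numbers so far, but its nearest neighbour is compound 1, and the step of a 2.0-fold higher number from compound 1 to compound 2 (0.30 log units; within the scatter) is within the scatter, so the two cannot be ordered. The change from compound 2 to compound 3, `COc1cc(/C=N/NC(=O)Nc2ccc(Oc3ccnc(-c4nncn4CCN(C)C)c3)c(F)c2)ccc1O`, is 4-hydroxy-3-methoxyphenyl in place of 2,4-dimethoxyphenyl on a carbon with a double bond to nitrogen. Going by the values given here, the only measured step that bears on it is the one from compound 1 to compound 2, which also altered the group on the carbon with a double bond to nitrogen and stayed within the scatter. Among the compounds with values here, on that single precedent, no step beyond the scatter is expected in this assay for compound 3, in either direction; the one earlier change at this position shifted nothing that could be distinguished from repeat variation. Compound 3 is therefore estimated at 7000 nM, with a plausible range of 2500 nM to 20000 nM, which means an expected step of a 1.1-fold higher number from compound 2 to compound 3 (0.02 log units; within the scatter).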

Compound 3, half-maximal inhibitory concentration: 5320 nM
For compound 3 the middle estimate is 1.3-fold (0.12 log units) above the measured one; measured number inside the range.
By their numbers in this assay, from the lowest: compounds 1, 3 and 2 (each within the scatter of the next).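

In this assay the place on a carbon with a double bond to nitrogen has now carried a third terminal group, giving a 1.2-fold lower number from compound 2 to compound 3 (0.10 log units; within the scatter) and a 1.6-fold higher number from compound 1 to compound 3 (0.20 log units; within the scatter). What the earlier pair did not show is that 4-hydroxy-3-methoxyphenyl, with a hydrogen-bond donor, can replace 2,4-dimethoxyphenyl, which has none, and still give a number that cannot be told apart from that of compound 2. The three terminal groups in compound 1, compound 2 and compound 3 therefore all read alike on this cytotoxicity measure, and nothing measured here offers an explanation for this.

The compounds shown leave open whether a terminal group of a different kind at this place, such as a benzoic acid carrying a carboxylic acid, an aminophenyl carrying a basic amine, or a saturated cyclohexyl ring, would give a step beyond the scatter. For the compounds shown here, they also leave open whether this lack of a distinguishable step would hold on any core other than the one these three compounds share.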